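A few compounds are considered here, and "the series" means these few. Any claim that something is new, unique, unknown or untested is made for them only; others in the source may bear on it.

Measured so far in a functional assay on HCT-116 cells (Homo sapiens) for inhibition; a higher number here means a weaker inhibitor, a lower number a stronger inhibitor:

- compound 1, `CCNC(=O)c1noc(-c2cc(C(C)C)c(O)cc2O)c1-c1cc(CNC)no1`: 164 nM
- compound 2, `CCNC(=O)c1noc(-c2cc(C(C)C)c(O)cc2O)c1-c1cc(CN(C)C)no1`: 92 nM
- compound 3, `CCNC(=O)c1noc(-c2cc(C(C)C)c(O)cc2O)c1-c1cc(CN(CC)CC)no1`: 38 nM

Compound 1 gives the largest of the three numbers in this assay, but its separation from compound 2 is small: the change of a 1.8-fold lower number from compound 1 to compound 2 (0.25 log units; within the scatter) stays within the scatter. Its separation from compound 3 is clearer, a 4.3-fold lower number from compound 1 to compound 3 (0.64 log units; beyond the scatter), and the step of a 2.4-fold lower number from compound 2 to compound 3 (0.38 log units; beyond the scatter) points the same way. Across these three, enlarging the substituents on the amine nitrogen has gone with lower numbers, though only the steps to compound 3 exceed the scatter.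

Compound 4, `CCNC(=O)c1noc(-c2cc(C(C)C)c(O)cc2O)c1-c1cc(CN2CCCCC2)no1`, is not yet measured. Its difference from compound 1 is piperidin-1-yl in place of methylamino on a saturated chain carbon bound to an aromatic carbon. The piperidin-1-yl group closes the two alkyl arms of the amine into one six-membered ring and removes the hydrogen-bond donor, as the diethylamino of compound 3 also does in its open form. For the measured compounds named here, the step from compound 1 to compound 3 is therefore the closest precedent, with the step to compound 2 as a weaker one in the same direction. A modest lowering is expected, of about the size seen for compound 3: the expected step is a 3.3-fold lower number from compound 1 to compound 4 (0.52 log units; beyond the scatter). Compound 4 is accordingly estimated at 50 nM in this assay, with a range of 20 nM to 130 nM.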

Compound 4, half-maximal inhibitory concentration: 93 nM
Compound 4: middle estimate off by 1.9-fold (0.27 log units), on the low side; the measured number falls inside the stated range.
By their numbers in this assay, from the lowest: compound 3; then compounds 2, 4 and 1 (each within the scatter of the next).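

At this saturated chain carbon bound to an aromatic carbon, piperidin-1-yl in place of methylamino gives a 1.8-fold lower number from compound 1 to compound 4 (0.25 log units; within the scatter) in this assay, and piperidin-1-yl in place of dimethylamino gives a 1.0-fold higher number from compound 2 to compound 4 (0.00 log units; within the scatter), so the ring form cannot be told apart from either of these smaller amines. Piperidin-1-yl in place of diethylamino gives a 2.4-fold higher number from compound 3 to compound 4 (0.39 log units; beyond the scatter), which shows that the result seen with the open diethylamino does not carry over to the six-membered ring. The earlier link between larger substituents on the amine nitrogen and lower numbers therefore does not extend to all four compounds, and compound 4 is the one that goes against it.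

On these data alone, whether a pyrrolidin-1-yl ring, a morpholin-4-yl ring or an open dipropylamino group would sit with compound 3 or with compound 4 remains open, so ring closure and substituent size cannot yet be separated at this position. No measurement at hand accounts for the difference between the open diethylamino and the closed piperidin-1-yl form.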